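The source may hold more compounds than are shown below. What is called first, only, known or untested is meant among the compounds shown, and "the series" means these compounds.

Measured so far: compound 1 `CC1=C(C(=O)OCc2ccccn2)C(c2cccc(O)c2)C2=C(CCCC2=O)N1` with 1.58; compound 2 `CC1=C(C(=O)OCc2cccnc2)C(c2cccc(O)c2)C2=C(CCCC2=O)N1` with 1.21; compound 3 `CC1=C(C(=O)OCc2cccnc2)C(c2ccccc2)C2=C(CCCC2=O)N1` with 2.35 in a physicochemical assay for lipophilicity, measured as octanol-water partition; on this read-out lower numbers stand for lower lipophilicity and higher numbers for higher lipophilicity.

Compound 1 stands second highest of the three; its nearest neighbour is compound 2 at a number 0.37 log units lower from compound 1 to compound 2 (beyond the scatter), its furthest compound 3. Compound 4 `CC1=C(C(=O)OCc2ccccn2)C(c2ccccc2[N+](=O)[O-])C2=C(CCCC2=O)N1` differs from compound 1 in one place: 2-nitrophenyl in place of 3-hydroxyphenyl on a saturated ring carbon. Among the compounds with values here, one measured step bears on this change, the removal of the hydroxy, which gave a number 1.14 log units higher from compound 2 to compound 3 (beyond the scatter). Within the data shown here, no measured step covers the entering 2-nitrophenyl. A step upward in this assay beyond the scatter is therefore expected, somewhat smaller than that of removing hydroxy alone. Compound 4 is estimated at 2.4, between 1.9 and 2.9, an expected step of a number 0.82 log units higher from compound 1 to compound 4 (beyond the scatter).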

Compound 4, partition coefficient: 1.88
The estimate for compound 4 lay 0.52 log units above the measured number, outside the stated range (below it).
By their numbers in this assay, from the lowest: compound 2; then compounds 1 and 4 (each within the scatter of the next); then compound 3.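

In this assay, 2-nitrophenyl in place of 3-hydroxyphenyl on this saturated ring carbon gives a number 0.30 log units higher from compound 1 to compound 4 (within the scatter) and so cannot be told apart from the hydroxy compound on this read-out. Removing the hydroxy alone, in the pyridin-3-yl series, had given a number 1.14 log units higher from compound 2 to compound 3 (beyond the scatter) and thus a large step, so losing the hydroxy need not move the number far when a nitro group enters. Nothing measured here explains this result.

As far as these compounds go, how an amine or a carboxylic acid on this aromatic ring would compare remains open. So does whether 2-nitrophenyl would behave the same way alongside pyridin-3-yl.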